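The source may report more compounds than this note shows. Statements on the series, on what has been measured and on what is new or still open speak of the compounds shown alone.

In a functional assay on CHO cells for antagonist activity at Glucagon receptor (Homo sapiens), read by cAMP accumulation, with stated times of 30 min and 45 min (a lower number here means a stronger inhibitor, a higher number a weaker inhibitor), compound 2 `C[C@H](c1ccc(C(=O)NCCC(=O)O)cc1)N1C(=O)C(c2cccc(Cl)c2)=N[C@]12CC[C@@H](C(C)(C)C)CC2` gives 480 nM, while compound 1 `C[C@H](c1ccc(C(=O)NCCC(=O)O)cc1)N1C(=O)C(c2cccc(C3CC3)c2)=N[C@]12CC[C@@H](C(C)(C)C)CC2` gives 340 nM; the two numbers lie within the scatter of one another, the step being a 1.4-fold higher number from compound 1 to compound 2 (0.15 log units; within the scatter). Compound 3 `C[C@H](c1ccc(C(=O)NCCC(=O)O)cc1)N1C(=O)C(c2ccccc2F)=N[C@]12CC[C@@H](C(C)(C)C)CC2` carries 2-fluorophenyl in place of 3-chlorophenyl on a carbon with a double bond to nitrogen. For the measured compounds named here, no measured step exchanges one substituted phenyl for another at that carbon, so the single recorded step a 1.4-fold higher number from compound 1 to compound 2 (0.15 log units; within the scatter) bears only loosely on this change, and no shift beyond the scatter is expected in this assay. Compound 3 is therefore estimated at 600 nM, with a range from 200 nM to 2000 nM. That amounts to an expected step of a 1.3-fold higher number from compound 2 to compound 3 (0.10 log units; within the scatter).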

Compound 3, half-maximal inhibitory concentration: 350 nM
Compound 3: middle estimate off by 1.7-fold (0.23 log units), on the high side; low and high end bracket the measured number.
By their numbers in this assay, from the lowest: compounds 1, 3 and 2 (each within the scatter of the next).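

In this assay, 2-fluorophenyl in place of 3-chlorophenyl gives a 1.4-fold lower number from compound 2 to compound 3 (0.14 log units; within the scatter) and 2-fluorophenyl in place of 3-cyclopropylphenyl gives a 1.0-fold higher number from compound 1 to compound 3 (0.01 log units; within the scatter) on the same carbon with a double bond to nitrogen. The earlier pair showed only 3-cyclopropylphenyl and 3-chlorophenyl at this carbon, whereas these steps show that 2-fluorophenyl also reads within the scatter of both. Nothing available explains these values. Still open, going by these compounds, is whether an unsubstituted phenyl or a pyridyl ring at this carbon would also stay within the scatter.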